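Shortening the Chain on the Cyano Compound

The compounds below may be only part of what the source reports. "The series", "measured", "known", "first", "only" and "open" are said of these compounds alone.

In a functional assay for inhibition, with Rattus norvegicus as the target (on this read-out lower numbers stand for stronger inhibition and higher numbers for weaker inhibition), compound 1 (`CC(/N=c1\c(O)c(O)\c1=N/c1ccccc1)C(C)(C)C`) gives 5400 nM and compound 3 (`CC(/N=c1\c(O)c(O)\c1=N/c1ccc(C#N)cc1)C(C)(C)C`) gives 520 nM as the lowest number shown. Compound 2 (`CC(/N=c1\c(O)c(O)\c1=N/c1ccc(OC(F)(F)F)cc1)C(C)(C)C`) has only a limit (> 30000 nM). Compound 4 (`CC(C)/N=c1\c(O)c(O)\c1=N/c1ccc(C#N)cc1`) carries methyl in place of tert-butyl on a saturated chain carbon bound to a double-bonded nitrogen and a saturated chain carbon. The measured steps change only an aromatic carbon: cyano in place of hydrogen (a 10-fold lower number from compound 1 to compound 3 (1.02 log units; beyond the scatter)) and trifluoromethoxy in place of hydrogen (an at least 5.5-fold higher number from compound 1 to compound 2 (0.74 log units; beyond the scatter)). Both are sizeable, yet neither touches this chain, so they give no direct measure of this change. A moderately higher number is expected, with wide uncertainty (a 2.9-fold higher number from compound 3 to compound 4 (0.46 log units; beyond the scatter)). Compound 4 is estimated at 1500 nM (expected range 350 nM to 6000 nM).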

Compound 4, half-maximal inhibitory concentration: 13700 nM
Estimate against measurement, compound 4: 9.1-fold (0.96 log units) below; measured number above the stated range.
By their numbers in this assay, from the lowest: compound 3; then compound 1; then compound 4. At a limit, above all of these: compound 2.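

On this chain, the change is large: replacing tert-butyl with methyl costs much of the inhibition (a 26-fold higher number from compound 3 to compound 4 (1.42 log units; beyond the scatter)). Going by these compounds alone, this is the first measured change away from the aromatic carbon, and it shows that the cyano group, present in both compounds, does not keep the number low once the 1,2,2-trimethylpropyl group becomes isopropyl. Nothing shown here accounts for this loss. As far as these compounds go, it remains open whether the step would be as large with hydrogen in place of cyano. From the compounds shown here alone, how a cyclohexyl group or a longer chain would read here is also open.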